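The compounds below may be only part of what the source reports. "The series", "measured", "known", "first", "only" and "open" are said of these compounds alone.

Compound 1 `O=C(/C=C/c1coc2cc(O)ccc2c1=O)NCc1ccc(F)cc1`: in a functional assay on HeLa cells (Homo sapiens) for inhibition, read by MTT assay, with a stated time of 48 h (a higher number here means a weaker inhibitor, a lower number a stronger inhibitor), compound 1 reaches only the limit > 100000 nM.
Compound 2 `Cc1ccccc1NC(=O)/C=C/c1coc2cc(O)ccc2c1=O`: in this assay compound 2 gives 8670 nM.

Compound 2 thus holds the only real number shown. The value of compound 1 sits at the limit of > 100000 nM in this assay, at which 1 of the 2 values shown sits. Compound 3 `O=C(/C=C/c1coc2cc(O)ccc2c1=O)Nc1ccccc1` differs from compound 2 by hydrogen in place of methyl on an aromatic carbon. Among the measured compounds shown here, the one measured step, an at least 11-fold lower number from compound 1 to compound 2 (1.06 log units; beyond the scatter), swapped the whole group on the amide nitrogen, so it bears only loosely on this far smaller change. The expected step is a 1.2-fold higher number from compound 2 to compound 3 (0.06 log units; within the scatter), not beyond the scatter. For compound 3 the estimate is 10000 nM, with a range from 4000 nM to 30000 nM.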

Compound 3, half-maximal inhibitory concentration: 9700 nM
Estimate against measurement, compound 3: 1.0-fold (0.01 log units) above, within the range that was stated.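

Hydrogen in place of methyl on this aromatic carbon gives a 1.1-fold higher number from compound 2 to compound 3 (0.05 log units; within the scatter) in this assay, so the methyl is not needed to keep the inhibition seen with compound 2. Phenyl in place of 4-fluorobenzyl on the amide nitrogen gives an at least 10-fold lower number from compound 1 to compound 3 (1.01 log units; beyond the scatter), so the large step seen earlier does not depend on that methyl. The value of compound 1 is a limit, so this step has no exact size: the limit of > 100000 nM in this assay, at which 1 of the 3 values shown sits.

As far as these compounds go, whether a methoxy group, a chlorine atom or an amine on this carbon would move the number beyond the scatter stays open. So does whether the same holds at the other carbons of the ring.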